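From a Bromine to a tert-Butyl Group

A few compounds are considered here, and "the series" means these few. Any claim that something is new, unique, unknown or untested is made for them only; others in the source may bear on it.

Of the compounds shown here, three sharing one core have been measured in a physicochemical assay for lipophilicity; a lower number here means a more polar compound, a higher number a more lipophilic compound. Compound 1 `CC(C)(C)c1ccc(CCCN2CC=C(CCC(=O)NO)C2=O)cc1` gives 2.7. Compound 2 `O=C(CCC1=CCN(Cc2ccc(F)cc2)C1=O)NO` gives 0.571, and compound 3 `O=C(CCC1=CCN(Cc2ccc(Br)cc2)C1=O)NO` gives 1.26. Among these three numbers compound 3 stands second highest: its nearest neighbour is compound 2, and the step of a number 0.69 log units higher from compound 2 to compound 3 (beyond the scatter) came with bromo in place of fluoro on an aromatic carbon. The furthest is compound 1, whose number lies well above that of compound 3.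

The next compound, compound 4 `CC(C)(C)c1ccc(CN2CC=C(CCC(=O)NO)C2=O)cc1`, has not yet been measured. It differs from compound 3 in one place: tert-butyl in place of bromo on an aromatic carbon. Among the measured compounds shown here, only one measured step bears on this change, the rise from compound 2 to compound 3 when bromo replaced fluoro. Compound 1 also carries tert-butyl, yet it differs from compound 4 in more than one place, so its value only helps to frame the range. A rise beyond the scatter is expected for compound 4, of about a number 0.74 log units higher from compound 3 to compound 4 (beyond the scatter). Compound 4 is therefore estimated at 2, between 1.5 and 2.6.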

Compound 4, distribution coefficient: 2.1
The estimate for compound 4 lay 0.10 log units below the measured number; the measured number falls inside the stated range.
By their numbers in this assay, from the lowest: compound 2; then compound 3; then compound 4; then compound 1.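

On this aromatic carbon of the shared core, three groups can now be ranked in this assay, with fluoro lowest, bromo in the middle and tert-butyl highest. The second change gives a number 0.84 log units higher from compound 3 to compound 4 (beyond the scatter) and is about the same size as the earlier change from fluoro to bromo, while the two changes together give a number 1.53 log units higher from compound 2 to compound 4 (beyond the scatter) and so count as a large step. The number therefore keeps rising past bromo, and this latest swap puts four heavy atoms where there was one, with no ring, hydrogen-bond donor, hydrogen-bond acceptor or net charge on either side.

Nothing available here explains why the number moves in this way. The compounds shown also leave open where an amine or a carboxylic acid on this same carbon would fall relative to these three groups.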